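Swapping the sulfur-linked aryl group: from dimethyl to chloro

The source may hold more compounds than are shown below. What is called first, only, known or untested is meant among the compounds shown, and "the series" means these compounds.

Measured so far:
Compound 1 `COc1ccc(SCc2ccc(C(=O)Nc3ccccc3N)cc2)cc1` gives 33.1% in a functional assay on SMMC-7721 cells (Homo sapiens) for inhibition, read by CCK-8 assay, with a stated time of 72 h, tested at 2 uM; on this read-out lower numbers stand for less inhibition of growth and higher numbers for more inhibition of growth at the one concentration tested.
Compound 2 `Nc1ccccc1NC(=O)c1ccc(CSc2cccc(F)c2)cc1` gives 18.6% in this assay.
Compound 3 `Cc1cc(C)cc(SCc2ccc(C(=O)Nc3ccccc3N)cc2)c1` gives 29.1% in this assay.

Compound 3 stands second highest of the three; its gap to compound 1 lies within the scatter, while the gap to compound 2 lies beyond it. Compound 4 `Nc1ccccc1NC(=O)c1ccc(CSc2ccc(Cl)cc2)cc1` differs from compound 3 by 4-chlorophenyl in place of 3,5-dimethylphenyl on a sulfur.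

Going by the values given here, two steps bear on this change. The exchange of the aryl group on the sulfur between compound 1 and compound 3 gave a number 4 percentage points lower from compound 1 to compound 3 (within the scatter), and the move away from a fluorine-bearing ring gave a number 10.5 percentage points higher from compound 2 to compound 3 (beyond the scatter). A chlorine-bearing ring may behave more like the fluorine case, so a modest drop is expected. Compound 4 is therefore expected to give about 24% in this assay, between 12% and 36%. That estimate corresponds to an expected step of a number 5.1 percentage points lower from compound 3 to compound 4 (within the scatter).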

Compound 4, percent growth inhibition at one concentration: 2.93%
Beside the measured number, compound 4's estimate is 21.1 percentage points above it, outside the stated range (below it).
By their numbers in this assay, from the lowest: compound 4; then compound 2; then compounds 3 and 1 (each within the scatter of the next).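

In this assay, the aryl group on the sulfur can do more than nudge the read-out: 4-chlorophenyl gives a number 26.2 percentage points lower from compound 3 to compound 4 (beyond the scatter) and a number 30.2 percentage points lower from compound 1 to compound 4 (beyond the scatter), leaving little growth inhibition. Carrying a halogen does not settle the outcome, since the change between two halogen-bearing rings still gives a number 15.7 percentage points lower from compound 2 to compound 4 (beyond the scatter). No measurement here explains this drop.

As far as these compounds go, it remains open how a ring bearing an amine or a carboxylic acid would read at this position. From the compounds shown here alone, a bromine in place of the chlorine is equally open.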